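This account rests on a few compounds, and the source may have more. Where it says the series, first, only, none or still open, it means among the compounds named here.

Compound 1 `COc1ccc(-n2ncnc2-c2cc(OC)c(OC)c(OC)c2)cc1` pairs two aromatic rings on a shared core, and in a functional assay on HL-60 cells (Homo sapiens) for antiproliferative activity, read by MTT assay, with a stated time of 72 h (on this read-out lower numbers stand for stronger inhibition and higher numbers for weaker inhibition), compound 1 gives 6200 nM. Among the two results in hand, compound 1 holds the only real number; the other result is a limit rather than a measurement. Compound 2 `CCOc1cccc(-c2ncnn2-c2cc(OC)c(OC)c(OC)c2)c1` is the one with that limit: for compound 2 this assay reports only > 10000 nM. Within the data shown here, this is the limit of > 10000 nM in this assay, at which 1 of the 2 values shown sits, so it tells only that compound 2 is not stronger than that boundary. Among the measured compounds shown here, no two measured compounds differ in a single place, so no measured step is available to lean on.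

Compound 3 `COc1cc(-c2ncnn2-c2ccc(Cl)cc2)cc(OC)c1OC` is the compound still to be measured. It differs from compound 1 by chloro in place of methoxy on an aromatic carbon of a six-membered aromatic ring of carbon only. Without a measured step of this kind, the expected change is small: the step from compound 1 to compound 3 is estimated at a 1.1-fold higher number from compound 1 to compound 3 (0.05 log units; within the scatter), within the usual scatter. On that basis compound 3 is expected to give about 7000 nM in this assay, with a range from 2000 nM to 20000 nM.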

Compound 3, half-maximal inhibitory concentration: > 10000 nM
Compound 3 was reported as a limit; the forecaster's own chance of this, stated with the estimate: 30%; middle value at least 1.4-fold (0.15 log units) from the limit.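

In this assay, among these compounds, placing chloro in place of methoxy on the aromatic carbon para to a large group gives an at least 1.6-fold higher number from compound 1 to compound 3 (0.20 log units; that floor lies within the scatter), the first step that can be read at this position. Compound 3 is recorded only as a limit, > 10000 nM, so this step has a floor but no true size, and that floor does not clear the usual scatter; the change brought no visible gain, yet the result cannot establish a real loss either. With this result, the measured set offers only one real number, and the same limit now covers most of it: the limit of > 10000 nM in this assay, at which 2 of the 3 values shown sit.

From the compounds shown here alone, how far compound 3 actually lies from compound 1 stays open, since only a value inside the range of this assay could settle it. Also open, going by these compounds, is what other groups at this same position would do, such as a hydroxyl, an amine, a carboxylic acid or a longer chain like butoxy, and whether any of them would give a stronger reading than methoxy on the same shared core.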